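The compounds below may be only part of what the source reports. "The series", "measured", "known", "first", "only" and "open" are said of these compounds alone.

Compound 3 `C=C1C[C@]23C[C@@]1(O)CC[C@@H]2c1cccc(C)c1[C@@H]3Cn1cc(-c2ccc(F)cc2)nn1` and compound 1 `C=C1C[C@]23C[C@@]1(O)CC[C@@H]2c1cccc(C)c1[C@@H]3Cn1cc(-c2ccc(OC)cc2)nn1` share one core and differ only on the outer ring: methoxy in place of fluoro on an aromatic carbon. In a functional assay on A549 cells (Homo sapiens) for cytotoxicity, read by MTT assay, with a stated time of 4 days (a higher number here means a weaker inhibitor, a lower number a stronger inhibitor), compound 3 gives > 20000 nM, which is a limit of the assay rather than a number. Compound 1 likewise gives > 20000 nM, again a limit. The step that the two limits leave unreadable from compound 3 to compound 1 therefore cannot be read, because of the limit of > 20000 nM in this assay, at which 3 of the 3 values shown sit. Compound 2 `C=C1C[C@]23C[C@@]1(O)CC[C@H]2c1ccc(O)c(C)c1[C@@H]3Cn1cc(-c2ccc(F)cc2)nn1` carries a different core, and the difference between the two cores is not broken down here. In this assay compound 2 gives > 20000 nM, which is also a limit. Compound 4 `C=C1C[C@]23C[C@@]1(O)CC[C@H]2c1ccc(O)c(C)c1[C@@H]3Cn1cc(-c2ccc(OC)cc2)nn1` arises from compound 2 by the same change, (methoxy in place of fluoro on an aromatic carbon). Since compound 1 and compound 3 both sit at the limit, no size for that change is known from the measured pair. Compound 4 is therefore expected to stay at the limit as well, with a step that the limit leaves unreadable from compound 2 to compound 4 that is estimated rather than measured. On that footing compound 4 is estimated at 30000 nM, expected to fall between 12000 nM and 100000 nM.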

Compound 4, half-maximal inhibitory concentration: > 20000 nM
Compound 4 ended at the assay's limit; the forecaster's own chance of this, stated with the estimate: 85%; the middle value does not contradict the limit.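

Going from compound 2 to compound 4 gives no readable step, and the size of the change from fluoro to methoxy stays unknown, because both compounds give a limit rather than a number: the limit of > 20000 nM in this assay, at which 4 of the 4 values shown sit. The compounds shown leave open how strongly any of them acts in this assay and whether 4-fluorophenyl or 4-methoxyphenyl makes any difference there.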